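Cytotoxicity series: aryl variation on the shared core

The source may report more compounds than this note shows. Statements on the series, on what has been measured and on what is new or still open speak of the compounds shown alone.

Measured so far in an ADME assay on HFF cells (Homo sapiens) for cytotoxicity, read by resazurin assay, with a stated time of 96 h; on this read-out higher numbers stand for lower toxicity in this test and lower numbers for higher toxicity in this test:
compound 1 `CN1CCN(c2ccc3nc(-c4ccc(-c5ccccc5)s4)c(-c4ccncc4)n3n2)CC1`: 6800 nM
compound 2 `CN1CCN(c2ccc3nc(-c4cccc(-c5ccccc5)c4)c(-c4ccncc4)n3n2)CC1`: 10900 nM
compound 3 `CN1CCN(c2ccc3nc(-c4cccc5ccccc45)c(-c4ccncc4)n3n2)CC1`: 21300 nM

Compound 3 gives the highest number of the three in this assay; compound 2 lies within the scatter of it, while compound 1 lies beyond the scatter on the lower side, as a 3.1-fold higher number from compound 1 to compound 3 (0.50 log units; beyond the scatter) shows. Compound 4 `CN1CCN(c2ccc3nc(-c4ccc5ncsc5c4)c(-c4ccncc4)n3n2)CC1` has not been measured. The change from compound 3 to compound 4 is 1,3-benzothiazol-6-yl in place of naphthalen-1-yl on an aromatic carbon.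

Going by the values given here, only one measured step bears on this change, the exchange of the group at this place from compound 1 to compound 3, which was a 3.1-fold higher number from compound 1 to compound 3 (0.50 log units; beyond the scatter). Compounds 2 and 3 show that another such exchange stayed within the scatter. The three measured exchanges at this place therefore moved the number only modestly, and a step of at most that size, in either direction, is expected for a 1.5-fold lower number from compound 3 to compound 4 (0.18 log units; within the scatter). Compound 4 is estimated at 14000 nM, with a range from 5500 nM to 36000 nM.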

Compound 4, half-maximal cytotoxic concentration: 17500 nM
Compound 4: middle estimate off by 1.3-fold (0.10 log units), on the low side; low and high end bracket the measured number.
By their numbers in this assay, from the lowest: compounds 1, 2, 4 and 3 (each within the scatter of the next, the first and the last beyond it).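

In this assay the step of a 1.2-fold lower number from compound 3 to compound 4 (0.09 log units; within the scatter) stays within the scatter, so at this place, in this one pair, the 1,3-benzothiazol-6-yl group with its five-membered aromatic ring and 2 hydrogen-bond acceptors reads like the all-carbon naphthalen-1-yl group. The step of a 2.6-fold higher number from compound 1 to compound 4 (0.41 log units; beyond the scatter) lies beyond the scatter and gives a second group, after naphthalen-1-yl, that stands clear of the 5-phenylthiophen-2-yl group of compound 1. No measurement at hand gives a reason for either step.

Every group shown at this place is aromatic, so the effect of a saturated amine, a carboxylic acid or a longer alkyl chain on this aromatic carbon remains open. Also open, as far as these compounds go, is whether these steps would hold with another group in place of the pyridin-4-yl group.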